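The compounds below may be only part of what the source reports. "The series", "measured", "known", "first", "only" and "open" are said of these compounds alone.

Compound 1, `CC1=C(C(=O)OCc2ccccc2)C(c2ccoc2)NC(=O)N1`, gives 41% in an assay on membranes from CHO cells for displacement of a labelled ligand from adenosine receptor A1 (Homo sapiens), read by scintillation counting, with a stated time of 60 min, tested at 1 uM; a lower number here means less inhibition, a higher number more inhibition at the concentration tested (going by the name of the read-out).
Compound 2, `CC1=C(C(=O)OCc2ccccc2)C(c2cccs2)NC(=O)N1`, gives 45% in this assay.
Compound 3, `CCSC(=O)C1=C(C)NC(=O)NC1c1ccoc1`, gives 3% in this assay.

Compounds 1 and 2 share one core and differ in a single place:
thiophen-2-yl in place of furan-3-yl on a saturated ring carbon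
That step amounted to a number 4 percentage points higher from compound 1 to compound 2 (within the scatter), so the two numbers cannot be told apart. Compound 3 stands lowest of the three; how its core differs from the core of compound 1 is not broken down here.

Compound 4, `CCSC(=O)C1=C(C)NC(=O)NC1c1cccs1`, has not yet been measured in this assay. It differs from compound 3 by
thiophen-2-yl in place of furan-3-yl on a saturated ring carbon
The surroundings of the place are described differently in the two pairs: here the ring atom beside it bears a (ethylsulfanyl)carbonyl group (5 heavy atoms), in the earlier pair it bears a large group. The change is therefore the same kind of change, not the same one.

For compound 4 the expected step is a number 3 percentage points higher from compound 3 to compound 4 (within the scatter) because a number 4 percentage points higher from compound 1 to compound 2 (within the scatter) stayed within the scatter. For compound 4 the estimated value in this assay is 6%, with a range from 0% to 18%.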

Compound 4, a percentage reported as inhibition, at one concentration (the size of the read-out at that concentration, not a potency): 6%
Beside the measured number, compound 4's estimate shows no gap at the digits printed; the measured number falls inside the stated range.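

In this assay, thiophen-2-yl in place of furan-3-yl on the saturated ring carbon gave a number 3 percentage points higher from compound 3 to compound 4 (within the scatter), so on the core bearing the (ethylsulfanyl)carbonyl group the change cannot be told from no change. Set beside the earlier pair, the same kind of change behaved alike on both cores: the same change on two cores in this assay, a number 4 percentage points higher (within the scatter) from compound 1 to compound 2 and a number 3 percentage points higher (within the scatter) from compound 3 to compound 4, 1 percentage points apart, within the scatter of two such steps. This shows only that, in these two pairs, the change left the percentage within the scatter; it does not show that the two rings are interchangeable on other cores, and as a read-out at a single concentration it says nothing about potency.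

The compounds shown leave open what other groups on that saturated ring carbon would do, such as a phenyl ring or a chain ending in an amine, since only furan-3-yl and thiophen-2-yl appear there. They also leave open whether a longer chain in place of the methyl group would alter the picture on either core.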